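Trimming the anilino substituent of a thiourea-linked sulfonamide

The source may hold more compounds than are shown below. What is called first, only, known or untested is meant among the compounds shown, and "the series" means these compounds.

In a functional assay on NCI-H1975 cells (Homo sapiens) for antiproliferative activity, read by MTT assay, with a stated time of 72 h (on this read-out lower numbers stand for stronger inhibition and higher numbers for weaker inhibition), three compounds have been measured. Compound 1 `COc1cc2ncnc(Nc3ccc(F)c(Br)c3)c2cc1OCCCCC(=O)Nc1ccc(S(N)(=O)=O)cc1` gives 31600 nM. Within the data shown here, compound 2 `CCc1ccc(Nc2ncnc3cc(OC)c(OCCCCC(=O)Nc4ccc(S(N)(=O)=O)cc4)cc23)cc1` gives 10300 nM, and the change a 3.1-fold lower number from compound 1 to compound 2 (0.49 log units; beyond the scatter) is the only single-point step available. Compound 3 `NS(=O)(=O)c1ccc(NC(=S)Nc2ccc3ncnc(Nc4ccc(Cl)c(C(F)(F)F)c4)c3c2)cc1` gives 11800 nM; its value lies within the scatter of compound 2 and beyond the scatter of compound 1, a higher number than compound 1 gives. Compound 4 `NS(=O)(=O)c1ccc(NC(=S)Nc2ccc3ncnc(Nc4cccc(Cl)c4)c3c2)cc1` differs from compound 3 by 3-chlorophenyl in place of 4-chloro-3-(trifluoromethyl)phenyl on a nitrogen on an aromatic ring. The step from compound 1 to compound 2 also swaps the aryl group on this nitrogen, though on a different linker, and it shifted the number modestly, so a similar-sized shift in either direction seems possible for compound 4. Compound 4 is therefore expected to give about 10000 nM, between 3000 nM and 35000 nM, a step of a 1.2-fold lower number from compound 3 to compound 4 (0.07 log units; within the scatter).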

Compound 4, half-maximal inhibitory concentration: 39800 nM
For compound 4 the middle estimate is 4.0-fold (0.60 log units) below the measured one, and the stated range ends below it.
By their numbers in this assay, from the lowest: compounds 2 and 3 (each within the scatter of the next); then compounds 1 and 4 (each within the scatter of the next).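

At this nitrogen on the thiourea-linked compounds, the aryl group matters as well: in this assay replacing 4-chloro-3-(trifluoromethyl)phenyl with 3-chlorophenyl gives a 3.4-fold higher number from compound 3 to compound 4 (0.53 log units; beyond the scatter) and so goes with weaker inhibition. Among these compounds, the only earlier step at this nitrogen was on the other linker, and it involved different aryl groups. No measurement shown explains this shift. The change alters the ring at two points at once, so the compounds shown cannot separate the two contributions. A 3-(trifluoromethyl)phenyl or 4-chlorophenyl group on the same nitrogen would help to pull them apart.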